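Adding a Methoxy Group to Compound 2

The source may report more compounds than this note shows. Statements on the series, on what has been measured and on what is new or still open speak of the compounds shown alone.

In an ADME assay on Vero cells (Chlorocebus sabaeus) for cytotoxicity, read by CellTiter-Glo, with a stated time of 72 h (a lower number here means that less compound is tolerated, a higher number that more compound is tolerated), compound 1 (`[O-][n+]1nc(NC2CCC2)[n+]([O-])c2ccccc21`) gives 8.9 ug/mL and compound 2 (`[O-][n+]1nc(N[C@@H]2C[C@H]3CC[C@@H]2C3)[n+]([O-])c2ccccc21`) gives 3.4 ug/mL as the lower of the two numbers, a gap beyond the usual scatter. Compound 3 (`COc1ccc2c(c1)[n+]([O-])nc(N[C@@H]1C[C@H]3CC[C@@H]1C3)[n+]2[O-]`) differs from compound 2 by methoxy in place of hydrogen on an aromatic carbon. Going by the values given here, no measured pair shows this change, so no shift beyond the scatter is expected in this assay in either direction. The estimated 1.2-fold higher number from compound 2 to compound 3 (0.07 log units; within the scatter) is therefore small. Compound 3 is estimated at 4 ug/mL with a range from 1.5 ug/mL to 10 ug/mL in this measurement.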

Compound 3, half-maximal cytotoxic concentration: > 50 ug/mL
Compound 3: only a limit was reported (the forecaster's own chance of this, stated with the estimate: 5%); middle value at least 12-fold (1.09 log units) away from the limit.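

In this assay, methoxy in place of hydrogen on an aromatic carbon gives an at least 14-fold higher number from compound 2 to compound 3 (1.16 log units; beyond the scatter), showing that this place on the shared core can strongly change how much compound the cells tolerate. The value for compound 3 is a limit of the assay, not a number: the limit of > 50 ug/mL in this assay, at which 1 of the 3 values shown sits. Going by these compounds, the full size of the step therefore stays unknown.

This single pair cannot show whether the shift is specific to methoxy or whether an amine or a chlorine atom at this place would do the same. It also leaves open whether methoxy would act alike on compound 1.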